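Amide side chains: from compound 3 to compound 4

The source may hold more compounds than are shown below. What is called first, only, known or untested is meant among the compounds shown, and "the series" means these compounds.

Values in a physicochemical assay for solubility, read by spectrophotometry, measured as kinetic solubility, at pH 8, tested at 500 uM; on this read-out lower numbers stand for lower solubility and higher numbers for higher solubility:
- compound 1 `CC(=O)N1CCC(NC(=O)c2ccncc2Nc2cc(-c3ccc4ccn(C)c4c3)c3nccnc3c2)CC1` gives 213 ug/mL
- compound 2 `CN1CC(NC(=O)c2ccncc2Nc2cc(-c3ccc4ccn(C)c4c3)c3nccnc3c2)CCC1=O` gives 253 ug/mL
- compound 3 `CC(=O)N1CC(CNC(=O)c2ccncc2Nc2cc(-c3ccc4ccn(C)c4c3)c3nccnc3c2)C1` gives 252 ug/mL

Compound 3 stands level with the other two within the scatter: the measured steps are a 1.2-fold higher number from compound 1 to compound 3 (0.07 log units; within the scatter) and a 1.0-fold lower number from compound 2 to compound 3 (0.00 log units; within the scatter), and a 1.2-fold higher number from compound 1 to compound 2 (0.07 log units; within the scatter) also stays within the scatter. No order among the three can be read from this assay.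

The next compound, not yet measured, is compound 4 `CN1CCC(N(C)C(=O)c2ccncc2Nc2cc(-c3ccc4ccn(C)c4c3)c3nccnc3c2)C1`. The change from compound 3 is methyl(1-methylpyrrolidin-3-yl)amino in place of ((1-acetylazetidin-3-yl)methyl)amino on a carbonyl carbon. In words, methyl(1-methylpyrrolidin-3-yl)amino stands in place of ((1-acetylazetidin-3-yl)methyl)amino on a carbonyl carbon.

All three measured steps bear on this change, since each exchanges the group on the amide-type nitrogen. None of them tests the entering group, so they give only indirect support. With a 1.2-fold higher number from compound 1 to compound 3 (0.07 log units; within the scatter) and a 1.0-fold lower number from compound 2 to compound 3 (0.00 log units; within the scatter) as the closest guides, no step beyond the scatter is expected in this assay. The estimated step is a 1.1-fold lower number from compound 3 to compound 4 (0.06 log units; within the scatter). For compound 4 the expected value is 220 ug/mL. The estimated range runs from 130 ug/mL to 270 ug/mL.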

Compound 4, solubility: 245 ug/mL
Estimate against measurement, compound 4: 1.1-fold (0.05 log units) below; low and high end bracket the measured number.
By their numbers in this assay, from the lowest: compounds 1, 4, 3 and 2 (each within the scatter of the next).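

For the compounds shown here, compound 4 is the first in the set with 0 hydrogen-bond donors in the group on the carbonyl carbon, and its side chain has no carbonyl, whereas compounds 1, 2 and 3 all keep the amide hydrogen and a side-chain carbonyl. In this assay this larger change in the group still gives only steps within the scatter (a 1.0-fold lower number from compound 3 to compound 4 (0.01 log units; within the scatter)) (a 1.0-fold lower number from compound 2 to compound 4 (0.01 log units; within the scatter)) (a 1.2-fold higher number from compound 1 to compound 4 (0.06 log units; within the scatter)), so the four compounds, now including a methyl on the amide nitrogen and a five-membered ring, cannot be put in any order. No supporting measurement accompanies these numbers that would explain the flat read-out.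

Compound 4 differs from compound 3 in the methyl on the amide nitrogen, the ring and the acetyl group all at once, so the share of each remains unresolved, and a flat sum could hide opposing contributions. Also open, going by these compounds, is whether a side chain carrying a carboxylic acid, a hydroxyl or a longer chain on the amide nitrogen would leave the scatter in this assay at all.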